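Trifluoromethyl Gives Way to 3,5-Dimethyl-1,2-oxazol-4-yl

The compounds below may be only part of what the source reports. "The series", "measured", "known", "first", "only" and "open" are said of these compounds alone.

Of the compounds shown here, three sharing one core have been tested in an ADME assay on A549 cells (Homo sapiens) for cytotoxicity, read by CellTiter-Glo; on this read-out higher numbers stand for lower toxicity in this test and lower numbers for higher toxicity in this test. Compound 1 `Cc1c(Cc2ccc(F)cc2)c(=O)oc2cc(OCC(O)CN3CCC(C(N)=O)CC3)ccc12` gives 89300 nM in this assay, compound 2 `Cc1c(Cc2ccc(Cl)cc2)c(=O)oc2cc(OCC(O)CN3CCC(C(N)=O)CC3)ccc12` gives 40000 nM, and compound 3 `Cc1c(Cc2ccc(C(F)(F)F)cc2)c(=O)oc2cc(OCC(O)CN3CCC(C(N)=O)CC3)ccc12` gives 89300 nM. Compound 3 thus stands level with compound 1 at the digits shown, the two together at the top of the three numbers, while a 2.2-fold higher number from compound 2 to compound 3 (0.35 log units; beyond the scatter).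

Compound 4 `Cc1noc(C)c1-c1ccc(Cc2c(C)c3ccc(OCC(O)CN4CCC(C(N)=O)CC4)cc3oc2=O)cc1` carries a new group at the same position: 3,5-dimethyl-1,2-oxazol-4-yl in place of trifluoromethyl on an aromatic carbon. The measured steps touching this place are small. Exchanging fluoro for trifluoromethyl produced no change at the digits printed from compound 1 to compound 3 (within the scatter), and the chloro-to-trifluoromethyl change gave only a modest shift. Going by the values given here, no measured step introduces a ring at this position, so the larger entering group lies outside what the three compounds show directly.

Given that every change at this site so far stayed within or barely beyond the scatter, compound 4 is expected to remain near compound 3 in this assay, with a 1.3-fold lower number from compound 3 to compound 4 (0.11 log units; within the scatter) expected to be small and of uncertain direction. Compound 4 is therefore estimated at 70000 nM, within a range from 25000 nM to 180000 nM.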

Compound 4, half-maximal cytotoxic concentration: 36900 nM
For compound 4 the middle estimate is 1.9-fold (0.28 log units) above the measured one, within the range that was stated.
By their numbers in this assay, from the lowest: compounds 4 and 2 (each within the scatter of the next); then compounds 1 and 3 (each within the scatter of the next).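

In this assay, going by these compounds alone, the only group at this place that brings in a ring, 3,5-dimethyl-1,2-oxazol-4-yl, does not stay level with the two highest compounds: the change gives a 2.4-fold lower number from compound 3 to compound 4 (0.38 log units; beyond the scatter) and, against fluoro, a 2.4-fold lower number from compound 1 to compound 4 (0.38 log units; beyond the scatter) in the same direction. Against chloro the same group gives a 1.1-fold lower number from compound 2 to compound 4 (0.04 log units; within the scatter) and so joins compound 2 at the low end of the four numbers, which means that the heavy-atom count of the group at this place does not order the results, with chloro going against any trend that rises or falls with that count. Nothing available here accounts for the shift seen with the ring.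

The compounds shown leave open whether the shift belongs to the aromatic ring itself or to its two methyl groups and its hetero atoms, a question that a plain phenyl ring or an unsubstituted 1,2-oxazol-4-yl at this place would address. They also leave open how the number responds to a group of another kind on this aromatic carbon, such as an amine or a carboxylic acid.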